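Notes on compound 3 ahead of its cytotoxicity reading

The source may report more compounds than this note shows. Statements on the series, on what has been measured and on what is new or still open speak of the compounds shown alone.

Measured so far:
- compound 1, `O=C(c1cccnc1)N1N=C(c2ccc(O)cc2)CC1c1ccc([N+](=O)[O-])cc1` — in an ADME assay on HepG2 cells (Homo sapiens) for cytotoxicity, read by MTT assay, with a stated time of 7 days (a lower number here means a stronger inhibitor, a higher number a weaker inhibitor), compound 1 gives 18600 nM
- compound 2, `O=C(c1cccnc1)N1N=C(c2ccc(O)cc2)CC1c1ccc(Br)cc1` — in this assay compound 2 gives 58700 nM

Within the data shown here, compound 2 holds the highest of the two numbers in this assay; its nearest neighbour is compound 1, and the single measured step runs a 3.2-fold higher number from compound 1 to compound 2 (0.50 log units; beyond the scatter), with bromo in place of nitro on an aromatic carbon.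

Compound 3, `O=C(c1cccnc1)N1N=C(c2ccc(O)cc2)CC1c1ccc(OCc2ccccc2)cc1`, is not yet measured. Its change from compound 2 is benzyloxy in place of bromo on an aromatic carbon.

Among the measured compounds shown here, the only step known concerns the exchange of nitro for bromo; no measured pair shows what a benzyloxy group does at this position, so that step gives no direct guide. On this basis the step from compound 2 to compound 3 in this assay is expected to be a 1.2-fold lower number from compound 2 to compound 3 (0.07 log units; within the scatter), that is, none beyond the scatter, with a wide margin of doubt in both directions.

Compound 3 is therefore estimated at 50000 nM in this assay, within a range from 15000 nM to 160000 nM.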

Compound 3, half-maximal inhibitory concentration: 11400 nM
Beside the measured number, compound 3's estimate is 4.4-fold (0.64 log units) above it, and the stated range ends above it.
By their numbers in this assay, from the lowest: compounds 3 and 1 (each within the scatter of the next); then compound 2.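

In this assay, the step with benzyloxy in place of bromo is a 5.1-fold lower number from compound 2 to compound 3 (0.71 log units; beyond the scatter) and lies beyond the scatter, so this position tolerates a group of 8 heavy atoms, including one six-membered aromatic ring of carbon only, where bromo has 1 heavy atom. The step with benzyloxy in place of nitro is a 1.6-fold lower number from compound 1 to compound 3 (0.21 log units; within the scatter) and lies within the scatter, so these two groups cannot be told apart here, while bromo is separated from both by steps beyond the scatter. Nothing measured here accounts for the difference between bromo and the other two groups.

The compounds shown do not separate the contributions of the ether oxygen and the terminal ring of benzyloxy, which a methoxy group or a directly attached phenyl ring at the same position would begin to address. They also leave open whether the trend holds for an amine, a carboxylic acid or a longer chain such as phenethyloxy, and what a change elsewhere on the shared core would do to the reading in this assay.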